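A few compounds are considered here, and "the series" means these few. Any claim that something is new, unique, unknown or untested is made for them only; others in the source may bear on it.

Compound 1, `COc1ccc(CNc2nc([Se]C)nc3ccccc23)cc1`: in a functional assay on HT-29 cells (Homo sapiens) for cytotoxicity, read by MTT assay, with a stated time of 72 h (on this read-out higher numbers stand for weaker inhibition of growth and lower numbers for stronger inhibition of growth), compound 1 gives > 100000 nM, which is a limit of the assay rather than a number.
Compound 2, `C[Se]c1nc(NCc2ccccc2)c2ccccc2n1`: in this assay compound 2 gives 81000 nM.
Compound 3, `CSc1nc(NCc2ccccc2)c2ccccc2n1`: in this assay compound 3 gives > 100000 nM, again a limit of the assay and not a number.

Going by the values given here, compound 2 therefore holds the only real number among the three; the other two sit at the limit of > 100000 nM in this assay, at which 2 of the 3 values shown sit. Compound 4, `CSc1ccc(CNc2nc([Se]C)nc3ccccc23)cc1`, has not yet been measured. It differs from compound 2 by methylsulfanyl in place of hydrogen on an aromatic carbon.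

Among the compounds with values here, two measured steps touch this change. Within the data shown here, the step of an at least 1.2-fold lower number from compound 1 to compound 2 (0.09 log units; that floor lies within the scatter) concerns the same position on the benzyl ring: there, a methoxy group in place of hydrogen went with the limit, and its removal gave the one real number. The step of an at least 1.2-fold higher number from compound 2 to compound 3 (0.09 log units; that floor lies within the scatter) concerns the other end of the molecule, where sulfur in place of selenium also led back to the limit. Neither step is larger than the scatter, so the evidence is thin, but the step from compound 1 to compound 2 points in the direction that a group added at that position of the benzyl ring tends to weaken growth inhibition or to push the value beyond the measurable range. The step from compound 2 to compound 4 is thus expected to be small and upward, a 1.2-fold higher number from compound 2 to compound 4 (0.09 log units; within the scatter). Compound 4 is expected to give about 100000 nM in this assay, with a likely range from 40000 nM to 250000 nM, and a fair chance that only a limit is reported.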

Compound 4, concentration for total growth inhibition: > 100000 nM
Compound 4 ended at the assay's limit (the forecaster's own chance of this, stated with the estimate: 55%); the middle value lies on the limit itself.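

In this assay, methylsulfanyl in place of hydrogen on the six-membered aromatic ring of carbon only, para to a large group, gives an at least 1.2-fold higher number from compound 2 to compound 4 (0.09 log units; that floor lies within the scatter), so methoxy and methylsulfanyl, two different groups at this position, now both go with a limit of the assay, although the floor of this step lies within the scatter. The comparison of compound 1 with compound 4 cannot be read, as both values are limits and not numbers, so the data do not rank methoxy against methylsulfanyl. Of the compounds shown, only compound 2, with hydrogen at this position, carries a real number: the limit of > 100000 nM in this assay, at which 3 of the 4 values shown sit.

From the compounds shown here alone, how far compound 4 really lies from compound 2 stays open, and so does whether any group at this position can shift the value beyond the scatter in either direction. Only hydrogen, methoxy and methylsulfanyl appear here, so the compounds shown say nothing about an amine or a carboxylic acid on this ring, or about a longer chain on the selenium in place of methyl.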